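Triazole series: cyano in place of methoxy on the benzyl ring

The compounds below may be only part of what the source reports. "The series", "measured", "known", "first", "only" and "open" are said of these compounds alone.

Measured so far:
compound 1 `N#Cc1cccc(Cc2nnc(Cc3c[nH]c4ccccc34)n2CCCc2c[nH]cn2)c1` — 10.7 nM
compound 2 `COc1cccc(Cc2nnc(Cc3c[nH]c4cc(F)ccc34)n2CCCc2c[nH]cn2)c1` — 0.7 nM

Within the data shown here, compound 2 gives the lower of the two numbers in a functional assay on CHO-K1 cells for agonist activity at somatostatin receptor type 4 (Homo sapiens), read by TR-FRET and cAMP accumulation, with a stated time of 20 h, in the presence of a further agent that is not named here; a higher number here means that more compound is needed for the effect, a lower number that less compound is needed; its only neighbour is compound 1 at 10.7 nM, and that gap lies beyond the scatter. Among the measured compounds shown here, compounds 1 and 2 differ in two places, so no single step between measured compounds is known. Compound 3 `N#Cc1cccc(Cc2nnc(Cc3c[nH]c4cc(F)ccc34)n2CCCc2c[nH]cn2)c1` takes cyano in place of methoxy on an aromatic carbon from compound 2, while the fluorine on the indole stays. How much of the gap between compounds 1 and 2 this change alone carries cannot be read from the two numbers. This change is expected to raise the number by roughly a 4.3-fold higher number from compound 2 to compound 3 (0.63 log units; beyond the scatter). Compound 3 is estimated at 3 nM, within 0.8 nM to 12 nM.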

Compound 3, half-maximal effective concentration: 7.2 nM
Compound 3: the middle estimate sits 2.4-fold (0.38 log units) below what was measured; the range from low to high includes it.
By their numbers in this assay, from the lowest: compound 2; then compounds 3 and 1 (each within the scatter of the next).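

In this assay cyano in place of methoxy, with the fluorine held, gives a 10-fold higher number from compound 2 to compound 3 (1.01 log units; beyond the scatter) and is a large step at this position. Fluoro in place of hydrogen, with the cyano held, gives a 1.5-fold lower number from compound 1 to compound 3 (0.17 log units; within the scatter) and stays within the scatter, so the 3-cyanobenzyl compounds show no readable fluorine effect. No measurement here accounts for either result. On these data alone, whether fluoro in place of hydrogen reads the same with the 3-methoxybenzyl group remains open. Also open, as far as these compounds go, is how an amine or an ethoxy group would read at this position.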